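Swapping One Side Chain for Another on a Shared Core

The source may hold more compounds than are shown below. What is called first, only, known or untested is meant among the compounds shown, and "the series" means these compounds.

Of the compounds shown here, two sharing a core have so far been measured in an ADME assay on MDCK cells (Canis lupus familiaris) for cytotoxicity, read by microscopy, with a stated time of 48 h; on this read-out lower numbers stand for higher toxicity in this test and higher numbers for lower toxicity in this test. Compound 1 `CCCCc1csc(CN[C@@H]2C[C@H]3C[C@@H]([C@H]2C)C3(C)C)c1` gives 12500 nM in this assay. Compound 2 `C=C(C)c1csc(CN[C@@H]2C[C@H]3C[C@@H]([C@H]2C)C3(C)C)c1` gives 25000 nM in this assay, the larger of the two numbers shown, although a 2.0-fold higher number from compound 1 to compound 2 (0.30 log units; within the scatter), so the two compounds cannot be told apart on this read-out. Compound 3 `CCCc1csc(CN[C@@H]2C[C@H]3C[C@@H]([C@H]2C)C3(C)C)c1` has not yet been measured. It differs from compound 2 in one place: propyl in place of 1-methylethenyl on an aromatic carbon. Within the data shown here, the only measured step, exchanging butyl for 1-methylethenyl, moved the read-out by less than the scatter, and propyl is again a chain of the same count as the group it replaces, now without the double bond. No step beyond the scatter is therefore expected, which is what the estimated change a 1.5-fold lower number from compound 2 to compound 3 (0.17 log units; within the scatter) expresses. Compound 3 is expected to give about 17000 nM in this assay, with a likely range from 8000 nM to 40000 nM.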

Compound 3, minimum cytotoxic concentration: 12500 nM
For compound 3 the middle estimate is 1.4-fold (0.13 log units) above the measured one; the measured number falls inside the stated range.
By their numbers in this assay, from the lowest: compounds 1, 3 and 2 (each within the scatter of the next).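

In this assay, taking away the double bond at this position gives a 2.0-fold lower number from compound 2 to compound 3 (0.30 log units; within the scatter) and so does not separate propyl from 1-methylethenyl on this aromatic carbon. Shortening the saturated chain gives no change at the digits printed from compound 1 to compound 3 (within the scatter) and adds a comparison the earlier compounds did not offer: butyl and propyl, two chains without a double bond, cannot be told apart on this read-out either. No supporting measurement is available to bear on these results. As far as these compounds go, all three groups compared here are made only of carbon and hydrogen, so it remains open whether an amine, a carboxylic acid or a chain much longer than butyl at this position would give a step beyond the scatter. From the compounds shown here alone, whether changes elsewhere on the shared core would move the read-out also remains open.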